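This account rests on a few compounds, and the source may have more. Where it says the series, first, only, none or still open, it means among the compounds named here.

Measured in a physicochemical assay for solubility, read by HPLC, using the shake flask method, measured as kinetic solubility, with a stated time of 20 h, at pH 6.5, tested at 200 uM; a lower number here means a less soluble compound, a higher number a more soluble compound:
Compound 1 `O=S(=O)(NCC1COC1)c1cccc(-c2ccc3nccc(-c4ccncc4)c3n2)c1`: 20000 nM
Compound 2 `NS(=O)(=O)c1cccc(-c2ccc3nccc(-c4ccncc4)c3n2)c1`: < 5000 nM, a limit

Compound 2 has no number, only a limit (the limit of < 5000 nM in this assay, at which 1 of the 2 values shown sits). Compound 3 `C[C@@H]1CN(S(=O)(=O)c2cccc(-c3ccc4nccc(-c5ccncc5)c4n3)c2)C[C@H](C)N1` carries 3,5-dimethylpiperazin-1-yl in place of amino on a sulfonyl sulfur. Within the data shown here, one measured step bears on this change: an at least 4.0-fold lower number from compound 1 to compound 2 (0.60 log units; beyond the scatter). Read in reverse, that step points to a higher number in this assay when compound 2 gains a group at this place, although the groups differ. The expected step is an at least 5.0-fold higher number from compound 2 to compound 3 (0.69 log units; beyond the scatter). The estimate for compound 3 is 25000 nM. The expected range for compound 3 runs from 6000 nM to 100000 nM.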

Compound 3, solubility: 180000 nM
The estimate for compound 3 lay 7.2-fold (0.86 log units) below the measured number; the measured number lies above the stated range.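

Substitution on the sulfonyl sulfur reaches further than the earlier pair showed: in this assay, 3,5-dimethylpiperazin-1-yl in place of amino gives an at least 36-fold higher number from compound 2 to compound 3 (1.55 log units; beyond the scatter). Compound 2 has no number there, only a limit: the limit of < 5000 nM in this assay, at which 1 of the 3 values shown sits. Set against ((oxetan-3-yl)methyl)amino, 3,5-dimethylpiperazin-1-yl gives a 9.0-fold higher number from compound 1 to compound 3 (0.95 log units; beyond the scatter), so the identity of the entering group counts, not merely the presence of a substituent. Still open, going by these compounds, is which part of 3,5-dimethylpiperazin-1-yl goes with this rise, a question that piperazin-1-yl without the methyl groups or morpholin-4-yl would address. On these data alone, whether its two defined stereocentres matter also remains open.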